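From isopropyl to butyl on the carbonyl of compound 1

This account rests on a few compounds, and the source may have more. Where it says the series, first, only, none or still open, it means among the compounds named here.

Measured in a functional assay on HL-60 cells (Homo sapiens) for inhibition, read by MTT assay, with a stated time of 72 h (on this read-out lower numbers stand for stronger inhibition and higher numbers for weaker inhibition), the compounds read as follows:
compound 1 `CC(C)C(=O)N1CCN(c2nnc3nncn3n2)CC1` gives 1610 nM
compound 2 `CCCNc1nnc2nncn2n1` gives 15100 nM
compound 3 `OCC(CO)(CO)Nc1nnc2nncn2n1` gives > 100000 nM as a limit of the assay and not a number

Only two of these results are true numbers, and compound 1 holds the lower of them. Compound 2 reads higher at 15100 nM and that gap from compound 1 lies beyond the usual scatter.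

Compound 4 `CCCCC(=O)N1CCN(c2nnc3nncn3n2)CC1` has not yet been measured. Its difference from compound 1 is butyl in place of isopropyl on a carbonyl carbon and it amounts to butyl in place of isopropyl on a carbonyl carbon. Among the compounds with values here, no measured pair shows what such a change does, so the expectation rests on compound 1 at 1610 nM and the modest size of the change. In this assay no step beyond the scatter is expected. The estimated step is a 1.1-fold higher number from compound 1 to compound 4 (0.05 log units; within the scatter) and it stays small. For compound 4 the estimate is 1800 nM with an expected range from 600 nM to 6000 nM when the measurement comes in.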

Compound 4, half-maximal inhibitory concentration: 3130 nM
Compound 4: the middle estimate sits 1.7-fold (0.24 log units) below what was measured; low and high end bracket the measured number.
By their numbers in this assay, from the lowest: compounds 1 and 4 (each within the scatter of the next); then compound 2. At a limit, above all of these: compound 3.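

In this assay, within the data shown here, the pair gives the first reading of a change on a carbonyl carbon whose other neighbours are an amide-type nitrogen in a ring. Butyl in place of isopropyl gives a step (a 1.9-fold higher number from compound 1 to compound 4 (0.29 log units; within the scatter)) that the read-out does not separate from repeat scatter, so going from isopropylcarbonyl to butylcarbonyl leaves the inhibition of these two compounds indistinguishable. Nothing measured here gives a cause for this step.

Going by these compounds, what a longer chain, a phenyl ring or an amine on this carbonyl would do stays open, as one step within the scatter does not reach that far. Among these compounds, also open is what the carbonyl itself contributes, as compound 2 differs from compound 1 in more than one place and no single-change pair addresses it.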